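Trading the Aryl Carbonyl for Acetyl on the Core

This account rests on a few compounds, and the source may have more. Where it says the series, first, only, none or still open, it means among the compounds named here.

Compound 1 `O=C(Nc1ccccc1C(F)(F)F)C1CCc2ccccc2N1C(=O)c1cccc(Cl)c1`: 526 nM
Compound 2 `O=C(Nc1ccccc1O)C1CCc2ccccc2N1C(=O)c1cccc(Cl)c1`: 17200 nM
Compound 3 `O=C(Nc1ccc(O)cc1)C1CCc2ccccc2N1`: > 100000 nM

In a functional assay on ACHN cells (Homo sapiens) for cytotoxicity, read by sulforhodamine B assay, with a stated time of 72 h (on this read-out higher numbers stand for weaker inhibition of growth and lower numbers for stronger inhibition of growth), compound 1 gives the lowest of the two numbers shown; its nearest neighbour is compound 2, and the step of a 33-fold higher number from compound 1 to compound 2 (1.51 log units; beyond the scatter) lies beyond the scatter. For compound 3 the value is a limit of this assay and not a number (the limit of > 100000 nM in this assay, at which 1 of the 3 values shown sits). Compound 3 differs from compound 1 in more than one place, so its limit is only noted.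

Compound 4 `CC(=O)N1c2ccccc2CCC1C(=O)Nc1ccccc1C(F)(F)F` is not yet measured in this assay. It differs from compound 1 by methyl in place of 3-chlorophenyl on a carbonyl carbon. Going by the values given here, no measured step touches this carbonyl carbon: the one step on record, from compound 1 to compound 2, sits on the aromatic ring at the other end of the core, so no direct guide to size or direction exists. With the 3-chlorophenyl gone and only methyl in its place, a weaker result is expected, with the step from compound 1 to compound 4 estimated as a 9.5-fold higher number from compound 1 to compound 4 (0.98 log units; beyond the scatter). Compound 4 is therefore expected to give about 5000 nM in this assay, within the range 1000 nM to 50000 nM.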

Compound 4, concentration for 50% growth inhibition: > 80000 nM
Compound 4 was reported as a limit; the forecaster's own chance of this, stated with the estimate: 15%; middle value at least 16-fold (1.20 log units) from the limit.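

Going by these compounds alone, putting methyl in place of 3-chlorophenyl on the carbonyl carbon gives an at least 150-fold higher number from compound 1 to compound 4 (2.18 log units; beyond the scatter), the first measured change at this position, and it shows that the position is far from indifferent. With the trifluoromethyl unchanged, the growth inhibition seen for compound 1 in this assay does not survive the loss of the 3-chlorophenyl, so the trifluoromethyl alone does not sustain it. The value of compound 4 is a limit and not a number: the limit of > 80000 nM in this assay, at which 1 of the 4 values shown sits.

With methyl as the only replacement, the compounds shown cannot tell whether the aromatic ring or its chlorine matters more; an unsubstituted phenyl, a cyclohexyl or a longer chain such as butyl on this carbonyl carbon would separate the two. On these data alone, it also remains open how hydroxy in place of trifluoromethyl would behave with acetyl on the core.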